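Removing a Methoxy Group from a Weakly Active Ester

The source may hold more compounds than are shown below. What is called first, only, known or untested is meant among the compounds shown, and "the series" means these compounds.

Compound 1 `CCOC(=O)C1=Cc2ccccc2OC1(OCc1cc(-c2ccc(F)cc2F)no1)C(F)(F)F` gives > 150000 nM in a functional assay on MCF7 cells (Homo sapiens) for inhibition, read by MTT assay, with a stated time of 24 h (a lower number here means a stronger inhibitor, a higher number a weaker inhibitor), which is a limit of the measurement rather than a number.
Compound 2 `CCOC(=O)C1=Cc2ccccc2OC1(OCc1cn(-c2cccc(OC)c2)nn1)C(F)(F)F` gives > 150000 nM in this assay, again a limit.
Compound 3 `Cc1ccc(-c2cc(COC3(C(F)(F)F)Oc4ccccc4C=C3C(=O)O)on2)cc1` gives 30100 nM in this assay.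

Compound 2 therefore stands at the edge of what this assay reports: its value is a limit, and the limit of > 150000 nM in this assay, at which 2 of the 3 values shown sit, places compound 1 at the same limit, so compound 2 cannot be ordered against compound 1. Compound 3 is the only one of the three with a number, and a weak one.

Compound 4 `CCOC(=O)C1=Cc2ccccc2OC1(OCc1cn(-c2ccccc2)nn1)C(F)(F)F` differs from compound 2 by hydrogen in place of methoxy on an aromatic carbon, meta to a large group. Within the data shown here, no step between measured compounds connects such a change to a number, so there is nothing to scale it by. The change is small, and compound 2 gives only > 150000 nM, so compound 4 is expected to remain near that limit; the expected step that the limit leaves unreadable from compound 2 to compound 4 is none beyond the scatter. Compound 4 is estimated at 200000 nM, within a range from 50000 nM to 800000 nM, and most likely reported only as a limit.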

Compound 4, half-maximal inhibitory concentration: > 150000 nM
Compound 4 was reported as a limit (the forecaster's own chance of this, stated with the estimate: 75%); the middle value is on the limit's open side.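

Compound 2 and compound 4 are both reported only as a limit, so no step can be read between them: the limit of > 150000 nM in this assay, at which 3 of the 4 values shown sit.

The compounds shown leave open whether the change from 3-methoxyphenyl to phenyl has any effect on inhibition in this assay.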